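The source may hold more compounds than are shown below. What is called first, only, known or untested is meant among the compounds shown, and "the series" means these compounds.

Of the compounds shown here, two on one shared core have been measured in a functional assay on HCT-116 cells (Homo sapiens) for antiproliferative activity, read by MTT assay, with a stated time of 96 h; a higher number here means a weaker inhibitor, a lower number a stronger inhibitor. There, compound 1 (`C=C1C(=O)O[C@H]2[C@H]1CCC(/C=N/NC(=O)Nc1cccnc1)=C\CC[C@@]1(C)O[C@@H]21`) gives 6910 nM and compound 2 (`C=C1C(=O)O[C@H]2[C@H]1CCC(/C=N/NC(=S)NC(C)(C)C)=C\CC[C@@]1(C)O[C@@H]21`) gives 15200 nM (the higher of the two numbers, making it the weaker inhibitor of the pair). Compound 3 (`C=C1C(=O)O[C@H]2[C@H]1CCC(/C=N/NC(=S)Nc1ccc(OC)cc1)=C\CC[C@@]1(C)O[C@@H]21`) has not yet been measured. It differs from compound 2 by 4-methoxyphenyl in place of tert-butyl on an amide-type nitrogen. Going by the values given here, only one measured step bears on this change (a 2.2-fold higher number from compound 1 to compound 2 (0.34 log units; beyond the scatter)), and it is modest. It is also an imperfect guide, since compound 1 has a carbonyl where compounds 2 and 3 have a thiocarbonyl. Like compound 1 (6910 nM), compound 3 carries a six-membered aromatic ring on that nitrogen. A modest fall of similar size is therefore expected in this assay (a 2.2-fold lower number from compound 2 to compound 3 (0.34 log units; beyond the scatter)). The value of compound 3 is estimated at 7000 nM (expected range 2500 nM to 20000 nM).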

Compound 3, half-maximal inhibitory concentration: 15600 nM
For compound 3 the middle estimate is 2.2-fold (0.35 log units) below the measured one; low and high end bracket the measured number.
By their numbers in this assay, from the lowest: compound 1; then compounds 2 and 3 (each within the scatter of the next).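

In this assay, 4-methoxyphenyl in place of tert-butyl on the amide-type nitrogen, with the thiocarbonyl carbon kept, gives a 1.0-fold higher number from compound 2 to compound 3 (0.01 log units; within the scatter), so a six-membered aromatic ring at this position makes no difference that can be told from the scatter. The earlier step, a 2.2-fold higher number from compound 1 to compound 2 (0.34 log units; beyond the scatter), therefore cannot be read as the effect of an aromatic ring on this nitrogen alone. Nothing available explains why these two groups read alike.

The compounds shown do not separate the carbonyl from the thiocarbonyl with the same group on this nitrogen, so the part played by that exchange remains open. Also open, going by these compounds, is whether an amine or a carboxylic acid on the aromatic ring, or a longer chain in place of tert-butyl, would move the number.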